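The compounds below may be only part of what the source reports. "The series", "measured", "known", "first", "only" and "open" are said of these compounds alone.

Measured compounds:
compound 1 `O=C(CCCCCc1ccccc1)c1nc2ccc(F)cc2o1` — 708 nM
compound 2 `O=C(CCCCCCc1ccccc1)c1nnc(-c2ccccc2)[nH]1` — > 10000 nM
compound 3 `CC(=O)c1coc(C(=O)CCCCCCc2ccccc2)n1` — 123 nM

All three were tested in an assay on HEK-293T cells for inhibition of diacylglycerol lipase-alpha (Homo sapiens), read by colorimetric assay; a higher number here means a weaker inhibitor, a lower number a stronger inhibitor. Compound 3 stands at the lowest of the two numbers recorded, with 123 nM; the nearest number belongs to compound 1, which sits at 708 nM, a gap beyond the usual scatter of the method. Compound 2 returns only a limit, > 10000 nM, which is the limit of > 10000 nM in this assay, at which 1 of the 3 values shown sits, and so contributes no number to set against the others. No two of these compounds differ in a single place, so no step between measured compounds can be drawn from them, and the spread among the three is left without a cause.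

Compound 4 `O=C(CCCCCCc1ccccc1)c1nc(Br)co1` has not yet been measured. It differs from compound 3 by bromo in place of acetyl on an aromatic carbon. In plain words, the change is bromo in place of acetyl on an aromatic carbon of a five-membered aromatic ring with 1 nitrogen and 1 oxygen. Nothing measured here tells what such an exchange does in this assay. Compound 4 is therefore expected to land near 300 nM, within a range from 80 nM to 1500 nM. The estimated step of a 2.4-fold higher number from compound 3 to compound 4 (0.39 log units; beyond the scatter) is expected to be modest and toward a weaker inhibitor, with wide uncertainty on either side.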

Compound 4, half-maximal inhibitory concentration: > 10000 nM
Compound 4: a limit, no number; the forecaster's own chance of this, stated with the estimate: 10%; middle value at least 33-fold (1.52 log units) away from the limit.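

In this assay, among these compounds, the exchange of acetyl for bromo on an aromatic carbon, next to the ring nitrogen, gives the only single-place comparison in this set: an at least 81-fold higher number from compound 3 to compound 4 (1.91 log units; beyond the scatter), a large step toward a weaker inhibitor. Compound 4 gives > 10000 nM, which is a limit of the assay and not a number, so the step has a lower bound and its full size cannot be read. This position is therefore not indifferent to its substituent, as acetyl here goes with a measurable value and bromo with a result that joins the other compound at the ceiling of the method: the limit of > 10000 nM in this assay, at which 2 of the 4 values shown sit.

Acetyl counts a hydrogen-bond acceptor and a double bond outside the ring while bromo has neither, but this single exchange cannot show whether the drop comes from losing acetyl or from bringing in bromo. As far as these compounds go, it also remains open how a methyl ester, a carboxylic acid, an amide or a plain hydrogen at this carbon would read in this assay.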